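The source may report more compounds than this note shows. Statements on the series, on what has been measured and on what is new or still open speak of the compounds shown alone.

In a functional assay on the whole organism with Mus musculus as the target, at a dose of 50 mg/kg by the oral route (on this read-out higher numbers stand for more inhibition at the one dose given (going by the name of the read-out) and lower numbers for less inhibition), compound 1 `CN(C)CCCCOc1ccccc1/C=C/c1cccc(Cl)c1` gives 23.9% and compound 2 `C(=C/c1ccccc1OCCCCN1CCCC1)\c1ccccc1` gives 87.5%. Compound 2 stands highest of the two numbers, and its nearest neighbour, compound 1, lies lower by a margin beyond the usual scatter. Since these two compounds differ in more than one place, nothing can be said about which part of their difference carries that gap.

Compound 3 `C(=C/c1ccccc1OCCCCN1CCNCC1)\c1ccccc1` has not yet been tested in this assay. It differs from compound 2 by piperazin-1-yl in place of pyrrolidin-1-yl on a saturated chain carbon, four bonds along the chain from an oxygen on an aromatic ring. Among the compounds with values here, no pair of measured compounds shows this change alone, so the size of its effect is unknown. A modest decrease is expected, though anything from a small to a sizeable drop would not surprise. Compound 3 is therefore estimated at 65%, within a range of 35% to 90%, which corresponds to an expected step of a number 22.5 percentage points lower from compound 2 to compound 3 (beyond the scatter).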

Compound 3, a percentage reported as inhibition, in the whole organism at one dose (the size of the read-out at that dose, not a potency): 0%
Beside the measured number, compound 3's estimate is 65 percentage points above it; measured number outside the range, below it.
By their numbers in this assay, from the lowest: compound 3; then compound 1; then compound 2.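

In this assay, within the data shown here, the exchange of pyrrolidin-1-yl for piperazin-1-yl gives the first step that can be read at this position, on a saturated chain carbon, four bonds along the chain from an oxygen on an aromatic ring: a number 87.5 percentage points lower from compound 2 to compound 3 (beyond the scatter). The read-out at this position therefore depends strongly on the group it carries, since this single change puts a six-membered non-aromatic ring with 2 hetero atoms and 1 hydrogen-bond donor in place of a five-membered non-aromatic ring with 1 hetero atom and 0 hydrogen-bond donors. No measurement at hand says which of these differences carries the step.

The compounds shown leave open whether piperidin-1-yl or morpholin-4-yl at this position would stay near compound 2 or fall towards compound 3. They also leave open whether a methyl group on the second nitrogen of piperazin-1-yl would change the result.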